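Moving the trifluoromethyl group: 2-(trifluoromethyl)benzyl to 3-(trifluoromethyl)benzyl

This account rests on a few compounds, and the source may have more. Where it says the series, first, only, none or still open, it means among the compounds named here.

Measured in a functional assay on U-373MG ATCC cells (Homo sapiens) for cytotoxicity, read by MTT assay; a higher number here means a weaker inhibitor, a lower number a stronger inhibitor:
- Compound 1 `Oc1ccc(CN(Cc2ccccc2)Cc2ccc(O)c3ncccc23)c2cccnc12` gives 357 nM
- Compound 2 `Oc1ccc(CN(Cc2ccccc2C(F)(F)F)Cc2ccc(O)c3ncccc23)c2cccnc12` gives 78 nM

Compound 2 holds the lower of the two numbers. Compound 3 `Oc1ccc(CN(Cc2cccc(C(F)(F)F)c2)Cc2ccc(O)c3ncccc23)c2cccnc12` differs from it as follows: 3-(trifluoromethyl)phenyl in place of 2-(trifluoromethyl)phenyl on a saturated chain carbon bound to an amine nitrogen. The group changes on a saturated chain carbon bound to an amine nitrogen. Among the compounds with values here, the one measured step that bears on this is a 4.6-fold lower number from compound 1 to compound 2 (0.66 log units; beyond the scatter), which added the trifluoromethyl group. Within the data shown here, no measured pair shows that group moving. Compound 3 keeps the group, so little change is expected, probably within the scatter. The estimated step is a 1.4-fold higher number from compound 2 to compound 3 (0.15 log units; within the scatter). Compound 3 is expected at 110 nM, with an estimated range of 40 nM to 300 nM.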

Compound 3, half-maximal inhibitory concentration: 65 nM
For compound 3 the middle estimate is 1.7-fold (0.23 log units) above the measured one, and the stated range covers the measured number.
By their numbers in this assay, from the lowest: compounds 3 and 2 (each within the scatter of the next); then compound 1.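

In this assay, moving the trifluoromethyl group gives a 1.2-fold lower number from compound 2 to compound 3 (0.08 log units; within the scatter) and so does not separate 2-(trifluoromethyl)phenyl from 3-(trifluoromethyl)phenyl on this saturated chain carbon bound to an amine nitrogen. Adding the group to compound 1 at the new place gives a 5.5-fold lower number from compound 1 to compound 3 (0.74 log units; beyond the scatter) and thus shows that the lower number seen earlier is not confined to the first placement. From the compounds shown here alone, whether a nitrile, a methoxy group or a carboxylic acid in place of trifluoromethyl would keep that lower number stays open. No supporting measurement explains why either placement lowers the number.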